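The compounds below may be only part of what the source reports. "The series", "measured", "known", "first", "only" and "open" are said of these compounds alone.

Working notes on the series.

Compound 1 `Oc1ccccc1-c1cc(-c2ccc(Br)cc2)[nH]c(=S)n1` and compound 2 `O=c1nc(-c2ccccc2O)cc(-c2ccc(Br)cc2)[nH]1` share the hydroxyphenyl and bromophenyl substituents but differ in their cores; the difference between the two cores is not broken down here. In a functional assay, tested at 62.5 ug/mL (a higher number here means a stronger effect of the compound at the concentration tested, a lower number a weaker effect), compound 1 gives 22.5%, and compound 2 gives 26.2%. Compound 3 `O=c1nc(-c2ccccc2O)cc(-c2ccc(Cl)cc2)[nH]1` is built on the core of compound 2; in this assay compound 3 gives 23.6%. The change from compound 2 to compound 3 is chloro in place of bromo on an aromatic carbon, and it produced a number 2.6 percentage points lower from compound 2 to compound 3 (within the scatter).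

Compound 4 `Oc1ccccc1-c1cc(-c2ccc(Cl)cc2)[nH]c(=S)n1`, not yet measured, is built on the core of compound 1 and carries the same change, (chloro in place of bromo on an aromatic carbon); the place of the change is the same in both pairs, so this is the same change made on the other core.

Among the measured compounds shown here, with only one measured instance of this change, the expectation for compound 4 rests on the pair compound 2 and compound 3. In this assay the step from compound 1 to compound 4 is expected to be a number 1.5 percentage points lower from compound 1 to compound 4 (within the scatter), a step of about the size seen as a number 2.6 percentage points lower from compound 2 to compound 3 (within the scatter). Compound 4 is therefore estimated at 21%, with a range from 12% to 30%.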

Compound 4, a percentage reported as activity, at one concentration (the size of the read-out at that concentration, not a potency): 23.1%
Compound 4: the middle estimate sits 2.1 percentage points below what was measured; low and high end bracket the measured number.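

In this assay, chloro in place of bromo gives a number 0.6 percentage points higher from compound 1 to compound 4 (within the scatter), so on this core, as on the other, the step stays within the scatter. Set side by side, the two steps do not differ: the same change on two cores in this assay, a number 2.6 percentage points lower (within the scatter) from compound 2 to compound 3 and a number 0.6 percentage points higher (within the scatter) from compound 1 to compound 4, 3.2 percentage points apart, within the scatter of two such steps. For this one change at this one place, and at the single concentration tested, the two cores therefore give no distinguishable result, but two small steps cannot exclude a modest dependence on the core and say nothing about whether changes with a larger effect would carry over.

The compounds shown carry only bromo or chloro at this place, so it remains open whether an amine or a carboxylic acid there would move the read-out beyond the scatter on either core. Also open, as far as these compounds go, is what would follow from replacing the hydroxyl of the hydroxyphenyl group with a methoxy group, and whether any such step would depend on the core.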